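This account rests on a few compounds, and the source may have more. Where it says the series, first, only, none or still open, it means among the compounds named here.

Of the compounds shown here, two sharing one core have been measured so far in a functional assay on Caco-2 cells (Homo sapiens) for inhibition, read by MTT assay, with a stated time of 48 h, tested at 10 uM (on this read-out lower numbers stand for less inhibition of growth and higher numbers for more inhibition of growth at the one concentration tested), and both sit low on that scale. Compound 1 `Cc1oc2c([C@H]3CCN(C)C[C@H]3O)c(O)cc(O)c2c(=O)c1C(O)c1ccccc1Br` gives 7% there, and compound 2 `Cc1oc2c([C@H]3CCN(C)C[C@H]3O)c(O)cc(O)c2c(=O)c1C(O)c1c(F)cccc1Cl` gives 18% there, the higher of the two numbers. The next compound changes one group. Compound 3 `Cc1oc2c([C@H]3CCN(C)C[C@H]3O)c(O)cc(O)c2c(=O)c1C(O)c1csc([N+](=O)[O-])c1` carries 5-nitrothiophen-3-yl in place of 2-chloro-6-fluorophenyl, on a saturated chain carbon bound to an aromatic carbon and an oxygen on a saturated carbon. Counted out, the difference is 5-nitrothiophen-3-yl in place of 2-chloro-6-fluorophenyl on a saturated chain carbon bound to an aromatic carbon and an oxygen on a saturated carbon and the rest of the structure stays the same. Going by the values given here, the only measured step at this place is a number 11 percentage points higher from compound 1 to compound 2 (beyond the scatter) and it is modest. That step exchanged one halogen-bearing phenyl group for another, while the entering group has a five-membered aromatic ring, so the step from compound 1 suggests a size but no direction. Among the compounds with values here, no measured compound carries a thiophene or a nitro group. The expected result is a number 5 percentage points lower from compound 2 to compound 3 (within the scatter) in this assay and no shift beyond the scatter is expected. For compound 3 the estimate is 13% with an expected range from 2% to 30% and a wide margin is kept for that reason.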

Compound 3, percent growth inhibition at one concentration: 3%
Estimate against measurement, compound 3: 10 percentage points above, within the range that was stated.
By their numbers in this assay, from the lowest: compounds 3 and 1 (each within the scatter of the next); then compound 2.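

In this assay, the position on a saturated chain carbon bound to an aromatic carbon and an oxygen on a saturated carbon can now be seen to move the number down as well as up: 5-nitrothiophen-3-yl in place of 2-chloro-6-fluorophenyl gives a number 15 percentage points lower from compound 2 to compound 3 (beyond the scatter), even though the two groups hold the same number of heavy atoms. Against 2-bromophenyl, the same entering group gives a number 4 percentage points lower from compound 1 to compound 3 (within the scatter), so these two quite different groups cannot be told apart here, and only 2-chloro-6-fluorophenyl stands clear of both others. Nothing available explains why these groups separate in this way.

On these data alone, what stays open is which part of the new group goes with the low number, the thiophene ring or the nitro group; a plain thiophen-3-yl group and a nitrophenyl group would pull those two apart. A plain phenyl group would likewise show what the halogens on the other two rings contribute, and an aminophenyl group would test whether a group other than halogen or nitro on the ring can lift the number at this position.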